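The compounds below may be only part of what the source reports. "The series", "measured", "known", "first", "only" and "open" are said of these compounds alone.

Measured in an ADME assay on MT4 cells (Homo sapiens) for cytotoxicity, read by MTT assay, with a stated time of 4 days; a lower number here means that less compound is tolerated, a higher number that more compound is tolerated:
- compound 1 `CCCNc1nc(C(C)c2c(F)cccc2F)c(C)c(=O)[nH]1`: 35000 nM
- compound 2 `O=c1cc(Cc2c(F)cccc2F)nc(N2CCCC2)[nH]1`: > 86000 nM
- compound 3 `O=c1cc(Cc2c(F)cccc2F)nc(N2CCC3(CC2)OCCO3)[nH]1`: > 69000 nM

Among the compounds with values here, compound 1 is the only compound with an actual number in this assay, 35000 nM. Compound 2 gives only a limit of the assay, > 86000 nM. Compound 3 likewise gives only a limit, > 69000 nM. Within the data shown here, the two limits leave the top of the range open, and no pair of measured compounds differs in one place, so the series offers no measured step to use as a guide.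

Compound 4 `Cc1c(C(C)c2c(F)cccc2F)nc(N(C)C(C)C)[nH]c1=O` keeps the core of compound 1 and changes one group: isopropyl(methyl)amino in place of propylamino on an aromatic carbon. In words, isopropyl(methyl)amino stands in place of propylamino on an aromatic carbon, between two ring nitrogen atoms.

Among the measured compounds shown here, with no measured step to draw on, the expectation starts from compound 1 at 35000 nM and stays close to it. The expected change in this assay is a 1.1-fold higher number from compound 1 to compound 4 (0.06 log units; within the scatter), which is estimated to stay within the usual scatter, with no firm direction. A report of only a limit is also possible. The estimate for compound 4 is 40000 nM, with an expected range from 15000 nM to 100000 nM.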

Compound 4, half-maximal cytotoxic concentration: > 81000 nM
Compound 4 gave a limit, no number; the forecaster's own chance of this, stated with the estimate: 30%; middle value at least 2.0-fold (0.30 log units) away from the limit.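

In this assay, within the data shown here, isopropyl(methyl)amino in place of propylamino on an aromatic carbon gives an at least 2.3-fold higher number from compound 1 to compound 4 (0.36 log units; beyond the scatter), the first measured step and the first evidence that a change at this position, between two ring nitrogen atoms, can move the reading beyond the scatter. The entering group has 0 hydrogen-bond donors against 1 for propylamino and 5 heavy atoms against 4, and this single step cannot separate those differences from one another or from the change in the shape of the group. The reading for compound 4 is a limit and not a number: the limit of > 81000 nM in this assay, at which 1 of the 4 values shown sits.

The size of the step above its printed minimum remains open, as does which feature of isopropyl(methyl)amino accounts for it. Open too, from the compounds shown here alone, is how other groups on the core of compound 1 would read at this position, for example dimethylamino, which has no hydrogen-bond donor, or butylamino, a longer chain that keeps one.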